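This account rests on a few compounds, and the source may have more. Where it says the series, first, only, none or still open, it means among the compounds named here.

Compound 1 `COc1ccc(C2=C(c3ccccn3)C(=O)N3CCCC3C2)cc1` in a functional assay on HCT-116 cells (Homo sapiens) for cytotoxicity; a higher number here means a weaker inhibitor, a lower number a stronger inhibitor: 104000 nM
Compound 2 `COc1ccc(C2=C(c3ccco3)C(=O)N3CCCC3C2)cc1` in this assay: 6000 nM

Among these two, compound 2 has the lowest number in this assay; its nearest neighbour is compound 1, and the step of a 17-fold lower number from compound 1 to compound 2 (1.24 log units; beyond the scatter) is large and beyond the scatter. Compound 3 `COc1ccc(C2=C(c3ccoc3)C(=O)N3CCCC3C2)cc1` is not yet measured. It differs from compound 2 in one place: furan-3-yl in place of furan-2-yl on a double-bonded ring carbon. Among the measured compounds shown here, the only measured step, a 17-fold lower number from compound 1 to compound 2 (1.24 log units; beyond the scatter), swaps one aromatic ring for another of a different kind on the same double-bonded ring carbon, and it shows that this position can respond strongly. The change to compound 3 is smaller in kind, the same ring attached through a different carbon, so a smaller step is expected, possibly within the scatter, and if anything towards a higher number. For compound 3 the estimate in this assay is 9000 nM, with a range from 3000 nM to 30000 nM. This estimate corresponds to an expected step of a 1.5-fold higher number from compound 2 to compound 3 (0.18 log units; within the scatter).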

Compound 3, half-maximal inhibitory concentration: 3000 nM
Compound 3: middle estimate off by 3.0-fold (0.48 log units), on the high side; the measured number falls inside the stated range.
By their numbers in this assay, from the lowest: compounds 3 and 2 (each within the scatter of the next); then compound 1.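

In this assay, moving the attachment point of the furan ring gives a 2.0-fold lower number from compound 2 to compound 3 (0.30 log units; within the scatter), so at this double-bonded ring carbon the two furan isomers cannot be told apart. The large gap to the pyridin-2-yl compound also holds for the second furan, with a 35-fold lower number from compound 1 to compound 3 (1.54 log units; beyond the scatter), which shows that the earlier step was not tied to furan-2-yl alone. No measurement is available that explains why both furans differ so much from pyridin-2-yl.

The compounds shown leave open how a thiophen-3-yl, phenyl or pyridin-3-yl ring would read at this same carbon in this assay. They also leave open what would follow if the methoxy group, the same in all three compounds, gave way to a hydroxyl group or a longer chain.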